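Working notes: dimethylamino to oxazolidinone at the diamino ring

A few compounds are considered here, and "the series" means these few. Any claim that something is new, unique, unknown or untested is made for them only; others in the source may bear on it.

Measured so far:
compound 1, `Cc1nn(-c2ccccc2)c2nc(O)c(-c3nc(N)cc(N)n3)cc12`: "not determined" (no result reported) in a functional assay on aorta (Rattus norvegicus, strain Sprague-Dawley); on this read-out higher numbers stand for an effect only at larger amounts of compound and lower numbers for an effect already at smaller amounts
compound 2, `Cc1nn(-c2ccccc2)c2nc(OCc3ccccc3F)c(-c3nc(N)c(N(C)C)c(N)n3)cc12`: 1100 nM

In this assay compound 2 gives 1100 nM and is the only number shown; compound 1 carries "not determined" (no result reported), so compound 2 has no measured neighbour to stand beside. Compound 3, `Cc1nn(-c2ccccc2)c2nc(OCc3ccccc3F)c(-c3nc(N)c(N4CCOC4=O)c(N)n3)cc12`, is the next entry to be measured in this assay. It differs from compound 2 in one place: 2-oxo-1,3-oxazolidin-3-yl in place of dimethylamino on an aromatic carbon. Among the measured compounds shown here, no step between measured compounds exists here to calibrate a change of this kind, and nothing in the numbers points to a direction. The expected step is a 1.4-fold higher number from compound 2 to compound 3 (0.13 log units; within the scatter), judged to lie within the usual scatter, perhaps leaning toward an effect only at a slightly larger amount of compound. Compound 3 is accordingly estimated at 1500 nM, with a range from 400 nM to 6000 nM.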

Compound 3, half-maximal effective concentration: > 100000 nM
Compound 3: a limit, no number; the forecaster's own chance of this, stated with the estimate: 10%; middle value at least 66-fold (1.82 log units) away from the limit.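

Compound 3 reads > 100000 nM in this assay, and this is a limit of the assay, not a number. Among the compounds shown here, this gives the first measured change at the aromatic carbon ortho to two amino groups: 2-oxo-1,3-oxazolidin-3-yl in place of dimethylamino gives an at least 90-fold higher number from compound 2 to compound 3 (1.95 log units; beyond the scatter), so in this pair the identity of the group at this position matters far beyond the scatter. The size of the step has no upper bound, and the step rests on a limit: the limit of > 100000 nM in this assay, at which 1 of the 3 values shown sits.

For the compounds shown here, with only this pair, the effect of the five-membered ring cannot be separated from that of its carbonyl or from the larger number of heavy atoms. Open-chain groups such as methylamino or acetamido, and a ring amine such as pyrrolidine, would each bear on that question at this position.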